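The compounds below may be only part of what the source reports. "The series", "measured", "known", "first", "only" and "open" are said of these compounds alone.

The three measured compounds share one core and differ only in the group attached to the amine nitrogen. Compound 1 `Cc1ccc2[nH]c(=O)c(CN(CCCO)Cc3ccc(C(C)(C)C)cc3)cc2c1` carries a 2-hydroxyethyl group there. In a toxicity assay on MDCK cells (Canis lupus familiaris) for cytotoxicity, read by crystal violet staining, with a stated time of 48 h (a lower number here means that less compound is tolerated, a higher number that more compound is tolerated), compound 1 gives only a limit, > 10000 nM. Compound 2 `COCOc1ccc(CN(Cc2ccc(C(C)(C)C)cc2)Cc2cc3cc(C)ccc3[nH]c2=O)cc1` carries a 4-(methoxymethoxy)phenyl group instead, and in this assay compound 2 gives 6400 nM. Compound 3 `CCCOc1ccc(CN(Cc2ccc(C(C)(C)C)cc2)Cc2cc3cc(C)ccc3[nH]c2=O)cc1` carries a 4-propoxyphenyl group, and in this assay compound 3 gives only a limit, > 5000 nM.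

Of the three steps, only one has a readable size: an at least 1.5-fold lower number from compound 1 to compound 2 (0.19 log units; that floor lies within the scatter). The other two are undecidable, since a step that the two limits leave unreadable from compound 1 to compound 3 and a step that the limit leaves unreadable from compound 2 to compound 3, because one of the ends sits at the limit of > 10000 nM in this assay, at which 1 of the 3 values shown sits, or at the limit of > 5000 nM in this assay, at which 1 of the 3 values shown sits.

Compound 4 `CCCCOc1ccc(CN(Cc2ccc(C(C)(C)C)cc2)Cc2cc3cc(C)ccc3[nH]c2=O)cc1` is not yet measured. It differs from compound 3 by methyl in place of hydrogen on a saturated chain carbon, three bonds along the chain from an oxygen on an aromatic ring. Among the measured compounds shown here, no measured step changes this part of the molecule, and the one neighbouring change, from compound 2 to compound 3, gave no readable size in this assay. On that basis the step that the limit leaves unreadable from compound 3 to compound 4 is expected to stay within the usual scatter. Compound 4 is therefore estimated at 8000 nM in this assay, with a range from 3000 nM to 30000 nM, and a limit rather than a number is the likelier outcome.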

Compound 4, half-maximal cytotoxic concentration: > 5000 nM
Compound 4 ended at the assay's limit; the forecaster's own chance of this, stated with the estimate: 60%; the middle value is on the limit's open side.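

In this assay, among the compounds shown here, compound 4 gives only a limit, so no step from compound 1, compound 2 or compound 3 to compound 4 can be read. The compounds shown leave open where the half-maximal cytotoxic concentrations of compound 1, compound 3 and compound 4 actually lie, and whether going from propyl to butyl changes the tolerated concentration at all.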